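A few compounds are considered here, and "the series" means these few. Any claim that something is new, unique, unknown or untested is made for them only; others in the source may bear on it.

Compound 1 `Cc1cc(C)cc(Cn2c(SCC(=O)Nc3ccccc3Br)nc3ccccc32)c1`: >= 143000 nM (a limit)
Compound 2 `Cc1cc(C)cc(Cn2c(SCC(=O)Nc3ccccc3Br)nc3ccc(Cl)cc32)c1`: 174000 nM
Compound 3 `Cc1cc(C)cc(S(=O)(=O)n2c(SCC(=O)Nc3ccc(C)cc3Cl)nc3ccc(Cl)cc32)c1`: > 234000 nM (a limit)

In an ADME assay on MT4 cells (Homo sapiens) for cytotoxicity (a higher number here means that more compound is tolerated, a lower number that less compound is tolerated), compound 1 gives >= 143000 nM, which is a limit of the assay and not an exact number. Compound 3 gives > 234000 nM, which is also a limit. Among the measured compounds shown here, compound 2 is the only one with an exact number, 174000 nM.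

Compound 4 `COC(=O)c1ccc(NC(=O)CSc2nc3ccccc3n2Cc2cc(C)cc(C)c2)c(Cl)c1` keeps the core of compound 1 and changes only the group on the amide-type nitrogen: 2-chloro-4-(methoxycarbonyl)phenyl in place of 2-bromophenyl on an amide-type nitrogen. In short, 2-chloro-4-(methoxycarbonyl)phenyl replaces 2-bromophenyl.

For the measured compounds named here, only one measured step is available as a guide: a step that the limit leaves unreadable from compound 1 to compound 2. It puts chloro in place of hydrogen on an aromatic carbon, its size cannot be read, and it does not touch the amide-type nitrogen. Going by the values given here, no measured step changes that group on its own, so the data point in neither direction for this assay.

The estimated at least 1.0-fold lower number from compound 1 to compound 4 (0.00 log units; that floor lies within the scatter) is therefore expected to stay within the usual scatter. A result reported only as a limit would be quite possible here. For compound 4 the expected value is 140000 nM, with an estimated range from 55000 nM to 280000 nM.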

Compound 4, half-maximal cytotoxic concentration: 191000 nM
Compound 4: the middle estimate sits 1.4-fold (0.13 log units) below what was measured, and the stated range covers the measured number.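

The step from compound 1 to compound 4 cannot be read, even though compound 4 has an exact number, because compound 1 is reported only as a limit: the limit of >= 143000 nM in this assay, at which 1 of the 4 values shown sits. The compounds shown leave open how large a change in this assay comes with 2-chloro-4-(methoxycarbonyl)phenyl replacing 2-bromophenyl, and in which direction.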